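The source may hold more compounds than are shown below. What is called first, only, known or untested is meant among the compounds shown, and "the series" means these compounds.

Compound 1, `NCCNc1cc(N2CCN(C(=O)CCc3ccccc3)CC2)nc2ccccc12`: > 100000 nM, a limit of the assay rather than a number.
Compound 2, `NCCNc1cc(N2CCN(C(=O)C3(c4ccccc4)CCC3)CC2)nc2ccccc12`: > 100000 nM, also a limit of the assay rather than a number.

Both values come from an ADME assay on HEp-2 cells (Homo sapiens) for cytotoxicity, read by CCK-8 assay, with a stated time of 6 days; on this read-out lower numbers stand for higher toxicity in this test and higher numbers for lower toxicity in this test. In this assay compound 1 gives only the limit > 100000 nM, so no toxic concentration was reached. Compound 2 likewise gives only the limit > 100000 nM. The step between them, a step that the two limits leave unreadable from compound 1 to compound 2, is therefore not readable in either size or direction. What the two results show together, (the limit of > 100000 nM in this assay, at which 2 of the 2 values shown sit), is just that: both compounds sit at the same limit.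

Compound 3, `CC(C)CC(=O)N1CCN(c2cc(NCCN)c3ccccc3n2)CC1`, differs from compound 1 in one place: isopropyl in place of benzyl on a saturated chain carbon bound to a carbonyl carbon. Among the measured compounds shown here, the only measured step, from compound 1 to compound 2, also swaps the group on the carbonyl carbon and ends at the limit, so it offers no size to carry over. What it does show is that two different groups at that position both left the cells untouched in this assay. For compound 3 the expected step is a number no higher from compound 1 to compound 3 (the limit leaves the size open), meaning no readable change. Compound 3 is estimated at 100000 nM, with a range of 40000 nM to 300000 nM, and most likely it too is reported only as a limit.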

Compound 3, half-maximal cytotoxic concentration: > 100000 nM
Compound 3 was reported as a limit; the forecaster's own chance of this, stated with the estimate: 85%; the middle value sits exactly at the limit.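

Compound 3, like compound 1 and compound 2, gives only a limit in this assay, so no step among these compounds can be read in either size or direction: the limit of > 100000 nM in this assay, at which 3 of the 3 values shown sit.

The compounds shown leave open at what concentration, if any, each one harms these cells, and whether swapping the group on the carbonyl carbon changes that concentration at all.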